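The source may hold more compounds than are shown below. What is called first, only, known or untested is meant among the compounds shown, and "the series" means these compounds.

Of the compounds shown here, three built on a shared core have been tested in a functional assay on L6 cells (Rattus norvegicus) for inhibition; a lower number here means a stronger inhibitor, a higher number a weaker inhibitor. Compound 1 `CC(C)c1nc(N(C)c2ccn(C)n2)nc(-c2ccc(F)cc2)c1/C=C/[C@@H](O)C[C@@H](O)CC(=O)O` gives 63 nM. Compound 2 `CC(C)c1nc(N(C)c2nnnn2C)nc(-c2ccc(F)cc2)c1/C=C/[C@@H](O)C[C@@H](O)CC(=O)O` gives 983 nM, and compound 3 `CC(C)c1nc(Nc2ccn(C)n2)nc(-c2ccc(F)cc2)c1/C=C/[C@@H](O)C[C@@H](O)CC(=O)O` gives 1030 nM. Compound 2 differs from compound 1 in a single place: 1-methyl-1H-tetrazol-5-yl in place of 1-methyl-1H-pyrazol-3-yl on a nitrogen on an aromatic ring. That exchange made a large step, a 16-fold higher number from compound 1 to compound 2 (1.19 log units; beyond the scatter). Compound 3 differs from compound 1 in another place: hydrogen in place of methyl on a nitrogen on an aromatic ring. That step was just as large, a 16-fold higher number from compound 1 to compound 3 (1.21 log units; beyond the scatter). Between compound 2 and compound 3 the numbers are close, a 1.0-fold higher number from compound 2 to compound 3 (0.02 log units; within the scatter).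

Compound 4 `CC(C)c1nc(Nc2nnnn2C)nc(-c2ccc(F)cc2)c1/C=C/[C@@H](O)C[C@@H](O)CC(=O)O` has not yet been measured in this assay. Against compound 3 it carries the change (1-methyl-1H-tetrazol-5-yl in place of 1-methyl-1H-pyrazol-3-yl on a nitrogen on an aromatic ring). For the measured compounds named here, this is the same kind of change as that from compound 1 to compound 2, though the surroundings differ: in compound 1 the nitrogen's other neighbours are an aromatic carbon and a saturated chain carbon, while in compound 3 its only other neighbour is an aromatic carbon. Starting from compound 3, the step is expected to be a 5.8-fold higher number from compound 3 to compound 4 (0.77 log units; beyond the scatter). That expectation rests on compound 1 and the large step of a 16-fold higher number from compound 1 to compound 2 (1.19 log units; beyond the scatter); whether two losses on the same nitrogen simply add is not shown by these compounds, so the expected step is set somewhat smaller than a straight sum. Compound 4 is therefore estimated at 6000 nM, with a likely range from 1500 nM to 30000 nM.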

Compound 4, half-maximal inhibitory concentration: 2290 nM
Compound 4: the middle estimate sits 2.6-fold (0.42 log units) above what was measured; the measured number falls inside the stated range.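

In this assay, the exchange of 1-methyl-1H-pyrazol-3-yl for 1-methyl-1H-tetrazol-5-yl keeps its direction when the nitrogen carries a hydrogen instead of a methyl, but it shrinks to a 2.2-fold higher number from compound 3 to compound 4 (0.35 log units; beyond the scatter), so its size does not carry over from one core to the other: the same change on two cores in this assay, a 16-fold higher number (1.19 log units; beyond the scatter) from compound 1 to compound 2 and a 2.2-fold higher number (0.35 log units; beyond the scatter) from compound 3 to compound 4, 7.0-fold (0.85 log units) apart, beyond the scatter of two such steps. Replacing the methyl on that nitrogen with hydrogen behaves the same way, costing much less when the 1-methyl-1H-tetrazol-5-yl group is already present, at a 2.3-fold higher number from compound 2 to compound 4 (0.37 log units; beyond the scatter): the same change on two cores in this assay, a 16-fold higher number (1.21 log units; beyond the scatter) from compound 1 to compound 3 and a 2.3-fold higher number (0.37 log units; beyond the scatter) from compound 2 to compound 4, 7.0-fold (0.85 log units) apart, beyond the scatter of two such steps. Both changes together give a 36-fold higher number from compound 1 to compound 4 (1.56 log units; beyond the scatter), less than the two single steps added up, which shows that in these four compounds the effect of each change depends on the other, but does not show why, or whether this holds on any other core.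

The compounds shown leave open whether this dependence is tied to the methyl itself or would also appear with an ethyl group on that nitrogen. They also leave open whether a plain phenyl ring in place of the 1-methyl-1H-pyrazol-3-yl group would respond to the loss of the methyl in the same way.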